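The source may hold more compounds than are shown below. What is called first, only, known or untested is meant among the compounds shown, and "the series" means these compounds.

Among the measured compounds shown here, compound 2 `CC(C)NC(=O)c1ccc(-c2cnc(N)c(-c3ccc(C#N)cc3)c2)cc1` gives 12.6 nM in an assay on Sf21 cells for inhibition of mitogen-activated protein kinase kinase kinase kinase 4 (Homo sapiens), read by ADP-Glo, with stated times of 30 min and 90 min (a lower number here means a stronger inhibitor, a higher number a weaker inhibitor), the lower of the two numbers known so far, and the gap to its only neighbour lies well beyond the usual scatter. That neighbour, compound 1 `CN(C)c1ncc(-c2ccc(O)cc2)cc1-c1ccc(S(C)(=O)=O)cc1`, gives 15800 nM in this assay. Compound 3 `CC(C)NC(=O)c1ccc(-c2cnc(N(C)C)c(-c3ccc(C#N)cc3)c2)cc1` differs from compound 2 by dimethylamino in place of amino on an aromatic carbon. For the measured compounds named here, no measured pair isolates this single change. The amino group that leaves is the one hydrogen-bond donor counted in that change, and a weakening is expected, so the step from compound 2 to compound 3 is estimated as a 120-fold higher number from compound 2 to compound 3 (2.08 log units; beyond the scatter). Compound 3 is expected to give about 1500 nM, within a range from 200 nM to 12000 nM.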

Compound 3, half-maximal inhibitory concentration: 20000 nM
Compound 3: middle estimate off by 13-fold (1.12 log units), on the low side, outside the stated range (above it).
By their numbers in this assay, from the lowest: compound 2; then compounds 1 and 3 (each within the scatter of the next).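

In this assay, dimethylamino in place of amino on this aromatic carbon, next to the ring nitrogen, gives a 1600-fold higher number from compound 2 to compound 3 (3.20 log units; beyond the scatter), so the position tolerates this change poorly. The change both removes the hydrogen-bond donor of amino and makes the group larger, and this single pair cannot separate those two differences. No measurement shown explains the loss.

Still open, from the compounds shown here alone, is whether compound 2 at 12.6 nM would largely keep this number with methylamino at this position, which would test a single methyl group on the nitrogen.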